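This account rests on a few compounds, and the source may have more. Where it says the series, first, only, none or still open, it means among the compounds named here.

Measured compounds: compound 1 `COc1cc(Cl)c(C(=O)N=C(N)N)cc1S(C)(=O)=O` with 40 nM; compound 2 `Cc1cc(Nc2ncccn2)c(S(C)(=O)=O)cc1C(=O)N=C(N)N` with 8.3 nM.

In a functional assay for inhibition of sodium/hydrogen exchanger (Oryctolagus cuniculus) (a higher number here means a weaker inhibitor, a lower number a stronger inhibitor), compound 2 gives 8.3 nM, the lowest of the two numbers, while compound 1 gives 40 nM, a higher number that lies beyond the scatter. Compound 3 `CS(=O)(=O)c1cc(C(=O)N=C(N)N)c(Cl)cc1Nc1ncccn1` differs from compound 2 by chloro in place of methyl on an aromatic carbon. Among the measured compounds shown here, no measured pair shows this change on its own, so only a small step is expected, in either direction or none beyond the scatter. Compound 3 is estimated at 7 nM in this assay, with a range from 2.5 nM to 20 nM. That amounts to an expected step of a 1.2-fold lower number from compound 2 to compound 3 (0.07 log units; within the scatter).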

Compound 3, half-maximal inhibitory concentration: 49 nM
Compound 3: the middle estimate sits 7.0-fold (0.85 log units) below what was measured; measured number outside the range, above it.
By their numbers in this assay, from the lowest: compound 2; then compounds 1 and 3 (each within the scatter of the next).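

In this assay, this aromatic carbon proves sensitive to a swap of one heavy atom: chloro in place of methyl gives a 5.9-fold higher number from compound 2 to compound 3 (0.77 log units; beyond the scatter). With chloro held fixed, (pyrimidin-2-yl)amino in place of methoxy gives a 1.2-fold higher number from compound 1 to compound 3 (0.09 log units; within the scatter), so that change shows no difference beyond the scatter here. No accompanying measurement accounts for either result.

As far as these compounds go, whether a fluoro, bromo or ethyl group on this carbon would read like methyl or like chloro remains open. So does whether the methyl-to-chloro step holds with methoxy in place of (pyrimidin-2-yl)amino.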